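The source may report more compounds than this note shows. Statements on the series, on what has been measured and on what is new or still open speak of the compounds shown alone.

Series notes, an assay on H4IIE cells for inhibition of phosphoenolpyruvate carboxykinase, cytosolic [GTP] (Rattus norvegicus); a lower number here means that less compound is needed, a higher number that more compound is needed for the effect:

- compound 1 `CCCCn1c(=O)n(Cc2ccccc2F)c(=O)c2[nH]c(Cc3ccc(NC(C)=O)cc3)nc21` gives 8600 nM
- compound 2 `Cc1nn(C)cc1S(=O)(=O)Nc1ccc(Cc2nc3c([nH]2)c(=O)n(Cc2ccccc2F)c(=O)n3CC2CC2)cc1` gives 5570 nM
- compound 3 `Cn1cc(S(=O)(=O)Nc2ccc(Cc3nc4c([nH]3)c(=O)n(Cc3ccccc3F)c(=O)n4CC3CC3)cc2)cn1` gives 8750 nM

The three numbers sit close together. Compound 3 holds the highest of the three, but its gap to compound 1 and its gap to compound 2 are both inside the scatter, so no order among the three can be claimed. Going by the values given here, the single one-point step measured so far is a 1.6-fold higher number from compound 2 to compound 3 (0.20 log units; within the scatter), a change of hydrogen in place of methyl on an aromatic carbon that left the read-out essentially where it was.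

Compound 4 `Cc1nc(N)sc1S(=O)(=O)Nc1ccc(Cc2nc3c([nH]2)c(=O)n(Cc2ccccc2F)c(=O)n3CC2CC2)cc1` is not yet measured. Relative to compound 3 the change is 2-amino-4-methyl-1,3-thiazol-5-yl in place of 1-methyl-1H-pyrazol-4-yl on a sulfonyl sulfur. Among the compounds with values here, no measured step covers the exchange of one five-membered aromatic ring for another at this position, and the step from compound 2 to compound 3 bears on it only insofar as it shows that a methyl on an aromatic carbon in this region made no difference beyond the scatter. With compound 1, compound 2 and compound 3 all lying within scatter of each other despite different groups on the aniline nitrogen, the expectation for compound 4 in this assay is a step of a 1.3-fold lower number from compound 3 to compound 4 (0.13 log units; within the scatter), that is, nothing clearly beyond the scatter. Compound 4 is therefore estimated at 6500 nM, with a range from 2500 nM to 17000 nM.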

Compound 4, half-maximal effective concentration: 8200 nM
The estimate for compound 4 lay 1.3-fold (0.10 log units) below the measured number; the range from low to high includes it.
By their numbers in this assay, from the lowest: compounds 2, 4, 1 and 3 (each within the scatter of the next).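

In this assay, the sulfonyl sulfur accepts a change of the whole five-membered aromatic ring without the read-out leaving the scatter: 2-amino-4-methyl-1,3-thiazol-5-yl in place of 1-methyl-1H-pyrazol-4-yl gives a 1.1-fold lower number from compound 3 to compound 4 (0.03 log units; within the scatter), and in place of 1,3-dimethyl-1H-pyrazol-4-yl it gives a 1.5-fold higher number from compound 2 to compound 4 (0.17 log units; within the scatter). The earlier step covered only a methyl on an aromatic carbon, whereas these two steps replace the ring itself and bring in a ring sulfur and an amino group, still with no change that can be told from the scatter. No supporting measurement is available to account for this result.

Among the sulfonamides shown, the sulfonyl sulfur always carries a five-membered aromatic ring, so it remains open how a phenyl ring, a plain methyl or a ring bearing a carboxylic acid would read at this place, and whether any group here moves the number beyond the scatter. The amino group and the methyl of 2-amino-4-methyl-1,3-thiazol-5-yl also enter together, so the contribution of each alone cannot be read from these compounds.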